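Amide aryl variation across a shared core

The compounds below may be only part of what the source reports. "The series", "measured", "known", "first", "only" and "open" are said of these compounds alone.

Values in a toxicity assay on HepG2 cells (Homo sapiens) for inhibition, read by CellTiter-Glo, with a stated time of 48 h; a higher number here means a weaker inhibitor, a lower number a stronger inhibitor:
compound 1 `COc1ccc2nc(C)cc(OCC(=O)Nc3cccc(C)c3)c2c1`: 39800 nM
compound 2 `COc1cccc(NC(=O)COc2cc(C)nc3ccc(OC)cc23)c1`: > 100000 nM, a limit of the assay rather than a number
compound 3 `COc1ccc2nc(C)cc(OCC(=O)Nc3ccc(F)cc3)c2c1`: 63100 nM

Compound 3 holds the highest of the two numbers in this assay, its nearest neighbour being compound 1, with a 1.6-fold higher number from compound 1 to compound 3 (0.20 log units; within the scatter). Compound 4 `COc1ccc2nc(C)cc(OCC(=O)Nc3ccncc3)c2c1` is not yet measured; it differs from compound 3 by pyridin-4-yl in place of 4-fluorophenyl on an amide-type nitrogen. Two measured steps change the aryl group on the same amide nitrogen: a 1.6-fold higher number from compound 1 to compound 3 (0.20 log units; within the scatter) and an at least 1.5-fold lower number from compound 2 to compound 3 (0.19 log units; that floor lies within the scatter), both within the scatter. The remaining step, an at least 2.5-fold higher number from compound 1 to compound 2 (0.40 log units; beyond the scatter), lies on the other side of the amide and is at least modest, with one value at the limit of > 100000 nM in this assay, at which 1 of the 3 values shown sits. Since aryl swaps on this nitrogen stayed within the scatter so far, compound 4 is expected close to compound 3, the estimated step being a 1.3-fold higher number from compound 3 to compound 4 (0.10 log units; within the scatter). Compound 4 is estimated at 80000 nM, ranging from 30000 nM to 200000 nM, with a fair chance of only a limit.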

Compound 4, half-maximal inhibitory concentration: > 100000 nM
Compound 4 ended at the assay's limit; the forecaster's own chance of this, stated with the estimate: 40%; middle value at least 1.2-fold (0.09 log units) away from the limit.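

In this assay compound 4 gives a limit, not a number, and it shares that limit with compound 2: the limit of > 100000 nM in this assay, at which 2 of the 4 values shown sit.
Pyridin-4-yl on the amide-type nitrogen gives an at least 1.5-fold higher number from compound 3 to compound 4 (0.19 log units; that floor lies within the scatter), and an at least 2.5-fold higher number from compound 1 to compound 4 (0.40 log units; beyond the scatter), so a swap of the aryl group on this nitrogen now reaches beyond the scatter from one measured neighbour only.
The step from compound 2 to compound 4 cannot be read.

As far as these compounds go, how far compound 4 and compound 2 lie past the limit remains open.
Also open, from the compounds shown here alone, is how a carboxylic acid or an amine on the aryl ring would read in this assay.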